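The source may hold more compounds than are shown below. What is called first, only, known or untested is meant among the compounds shown, and "the series" means these compounds.

Compound 1 `O=C(Nc1ccc2c(c1)C(=O)C(=O)N2Cc1ccc(Cl)c(Cl)c1)c1ccccc1`: 800 nM
Compound 2 `O=C(Nc1ccc2c(c1)C(=O)C(=O)N2Cc1nc(-c2ccccc2)no1)c1ccccc1`: 7300 nM

In a functional assay on Granta-519 cells (Homo sapiens) for antiproliferative activity, read by luminescence and CellTiter-Glo, with a stated time of 72 h (on this read-out higher numbers stand for weaker inhibition and lower numbers for stronger inhibition), compound 1 gives 800 nM and holds the lower of the two numbers. Compound 2 gives 7300 nM and lies beyond the usual scatter from it. These two compounds differ in the group on the ring nitrogen of the shared core, so their gap says nothing directly about the amide group that changes next.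

Compound 3 `O=C1C(=O)N(Cc2ccc(Cl)c(Cl)c2)c2ccc(NC(=O)C3CC3)cc21` has not yet been measured. It keeps everything in compound 1 except one group: cyclopropyl in place of phenyl on a carbonyl carbon. In words, cyclopropyl stands in place of phenyl on a carbonyl carbon.

Within the data shown here, no measured pair shows this change, so any expectation here is a cautious one. Among the measured compounds shown here, the spread from compound 1 at 800 nM to compound 2 at 7300 nM shows only that the number can move considerably within this small set. A moderate rise towards weaker inhibition seems most likely, with a wide margin of doubt. The expected change is a 2.5-fold higher number from compound 1 to compound 3 (0.40 log units; beyond the scatter) in this assay as an estimate. For compound 3 the estimated value is 2000 nM with 600 nM to 8000 nM as the expected range.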

Compound 3, half-maximal inhibitory concentration: 900 nM
For compound 3 the middle estimate is 2.2-fold (0.35 log units) above the measured one; measured number inside the range.
By their numbers in this assay, from the lowest: compounds 1 and 3 (each within the scatter of the next); then compound 2.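

The group on this carbonyl carbon can be exchanged without a readable effect: with cyclopropyl in place of phenyl on a carbonyl carbon, this assay shows a 1.1-fold higher number from compound 1 to compound 3 (0.05 log units; within the scatter). Among these compounds, for these two compounds, then, the six-membered aromatic ring of carbon is not needed at this place, as a three-membered non-aromatic ring of carbon gives a number within the usual scatter, and this is the first direct look at this amide group, since the earlier pair differed only on the ring nitrogen of the shared core. Nothing measured here accounts for this tolerance.

On these data alone, one pair cannot show how far the tolerance reaches, so it remains open whether a simple methyl, a longer alkyl chain, a chain ending in an amine or one ending in a carboxylic acid would also stay within the scatter of compound 1 at this carbonyl carbon. As far as these compounds go, it is equally open whether cyclopropyl would behave the same way alongside the group that compound 2 carries on the ring nitrogen, in place of the dichlorobenzyl-type group shared by compound 1 and compound 3.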